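Swapping the indole acyl group for a phenylethenyl group

The source may hold more compounds than are shown below. What is called first, only, known or untested is meant among the compounds shown, and "the series" means these compounds.

Measured so far:
compound 1 `CCCCCCCCCCCCNC(=O)[C@@H](NC(=O)/C=C/c1ccccc1)[C@@H](C)O`: 200000 nM
compound 2 `CCCCCCCCCCCCCCNC(=O)[C@@H](NC(=O)c1cc2ccccc2n1C)[C@@H](C)O`: 21500 nM

In a functional assay on SW-620 cells (Homo sapiens) for cytotoxicity, read by MTT assay, with a stated time of 48 h (on this read-out lower numbers stand for stronger inhibition and higher numbers for weaker inhibition), compound 2 gives 21500 nM, the lower of the two numbers recorded. Compound 1 gives 200000 nM in this assay, a markedly higher number that lies well beyond the usual scatter, so compound 2 stands as the stronger of the pair on this read-out.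

Compound 3 `CCCCCCCCCCCCCCNC(=O)[C@@H](NC(=O)/C=C/c1ccccc1)[C@@H](C)O` has not yet been measured. It differs from compound 2 by a single change: 2-phenylethenyl in place of 1-methyl-1H-indol-2-yl on a carbonyl carbon. This is the same acyl group carried by compound 1, the weaker of the two measured compounds, while the long chain of compound 3 matches that of compound 2.

Because compound 1 gives 200000 nM with this same 2-phenylethenyl group, compound 3 is expected to sit near compound 1 rather than compound 2, and the step is expected to be a clear move toward weaker inhibition, a 7.0-fold higher number from compound 2 to compound 3 (0.84 log units; beyond the scatter). Compound 3 is estimated at 150000 nM in this assay, with a range from 40000 nM to 400000 nM.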

Compound 3, half-maximal inhibitory concentration: 200000 nM
Compound 3: middle estimate off by 1.3-fold (0.12 log units), on the low side; low and high end bracket the measured number.
By their numbers in this assay, from the lowest: compound 2; then compounds 1 and 3 (each within the scatter of the next).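

In this assay, among the compounds shown here, 2-phenylethenyl in place of 1-methyl-1H-indol-2-yl on the carbonyl carbon gives a 9.3-fold higher number from compound 2 to compound 3 (0.97 log units; beyond the scatter) with the long chain held the same, so the gap seen between the earlier compounds now appears at a single change of acyl group. With 2-phenylethenyl on the carbonyl, ethyl in place of hydrogen on a saturated chain carbon gives no change at the digits printed from compound 1 to compound 3 (within the scatter) in this comparison, so these two chain lengths do not separate with this acyl group. Nothing measured here gives a reason for the difference between the two acyl groups.

Whether chain length counts with 1-methyl-1H-indol-2-yl on the carbonyl remains open, as that acyl group is shown with one chain only. Also open, on these data alone, is how a plain 1H-indol-2-yl group without the methyl, or an amine at the end of the chain, would read in this assay on the shared core.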